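The source may report more compounds than this note shows. Statements on the series, on what has been measured and on what is new or still open speak of the compounds shown alone.

In a functional assay on NCI-H441 cells (Homo sapiens) for antiproliferative activity, with a stated time of 24 h (on this read-out lower numbers stand for stronger inhibition and higher numbers for weaker inhibition), compound 1 `O=C1/C(=C/c2ccccc2F)CN(C(=O)c2ccccc2C(=O)O)C/C1=C\c1ccccc1F` gives 56000 nM and compound 2 `O=C1/C(=C/c2ccccc2F)CN(C(=O)C2CCCCC2C(=O)O)C/C1=C\c1ccccc1F` gives 55000 nM on the shared core, so compound 2 stands level with compound 1. Among the measured compounds shown here, the only measured step, a 1.0-fold lower number from compound 1 to compound 2 (0.01 log units; within the scatter) (within the scatter), puts 2-carboxycyclohexyl in place of 2-carboxyphenyl. Compound 3 `O=CN1C/C(=C\c2ccccc2F)C(=O)/C(=C/c2ccccc2F)C1` carries hydrogen in place of 2-carboxycyclohexyl on a carbonyl carbon. For the measured compounds named here, no measured step removes this group, so the guidance is weak. A moderately lower number is expected in this assay, the estimated move being a 3.7-fold lower number from compound 2 to compound 3 (0.56 log units; beyond the scatter) in size. For compound 3 the estimate is 15000 nM with an expected range from 3000 nM to 60000 nM overall.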

Compound 3, half-maximal inhibitory concentration: 49000 nM
Compound 3: middle estimate off by 3.3-fold (0.51 log units), on the low side; the range from low to high includes it.
By their numbers in this assay, from the lowest: compounds 3, 2 and 1 (each within the scatter of the next).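

In this assay the substituent on the carbonyl carbon can be stripped to hydrogen, leaving formyl, with no shift outside the scatter: hydrogen for 2-carboxycyclohexyl gives (a 1.1-fold lower number from compound 2 to compound 3 (0.05 log units; within the scatter)) and hydrogen for 2-carboxyphenyl gives (a 1.1-fold lower number from compound 1 to compound 3 (0.06 log units; within the scatter)). Across these three compounds, neither the ring nor the carboxylic acid on it is needed to hold the number at this level. No evidence on hand bears on this flat response.

Still open, from the compounds shown here alone, is whether any group on this carbonyl carbon can move the number beyond the scatter. A basic amine or a longer alkyl chain in this place would test that, and the rest of the shared core is untouched by these compounds.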